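This account rests on a few compounds, and the source may have more. Where it says the series, first, only, none or still open, it means among the compounds named here.

In an ADME assay on Vero cells (Chlorocebus sabaeus) for cytotoxicity, read by MTT assay, with a stated time of 72 h (on this read-out lower numbers stand for higher toxicity in this test and higher numbers for lower toxicity in this test), compound 2 (`CC(C)CN(CC(C)C)N1CCN(c2nc(=O)c3cc(C(F)(F)F)cc([N+](=O)[O-])c3s2)CC1`) gives > 64 ug/mL as a limit of the assay and not a number. Compound 3 (`O=c1nc(N2CCN(NCc3cccc(C(F)(F)F)c3)CC2)sc2c([N+](=O)[O-])cc(C(F)(F)F)cc12`) gives > 64 ug/mL as a limit too. Compound 1 (`O=c1nc(N2CCN(NCC3CCCCC3)CC2)sc2c([N+](=O)[O-])cc(C(F)(F)F)cc12`) gives a true number of 29.3 ug/mL in the same test. Two steps start from it: an at least 2.1-fold higher number from compound 1 to compound 2 (0.33 log units; beyond the scatter) and an at least 2.1-fold higher number from compound 1 to compound 3 (0.33 log units; beyond the scatter) both end at the limit of > 64 ug/mL in this assay, at which 2 of the 3 values shown sit, and so show only a lower bound on their size. Compound 4 (`O=c1nc(N2CCN(NCc3cc(F)cc(F)c3)CC2)sc2c([N+](=O)[O-])cc(C(F)(F)F)cc12`) carries (3,5-difluorobenzyl)amino in place of diisobutylamino on an amine nitrogen in a ring. For the measured compounds named here, the closest precedent is a step that the two limits leave unreadable from compound 2 to compound 3 and it also brings in a benzylamino group. No step beyond the scatter is expected in this assay and the estimate is an at least 1.1-fold lower number from compound 2 to compound 4 (0.06 log units; that floor lies within the scatter) for this change. Compound 4 is expected at about 55 ug/mL with an estimated range of 22 ug/mL to 110 ug/mL on this reasoning.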

Compound 4, half-maximal cytotoxic concentration: > 64 ug/mL
Compound 4: no number, only a limit; the forecaster's own chance of this, stated with the estimate: 55%; middle value at least 1.1-fold (0.06 log units) from the limit.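

In this assay, compound 4 gives only a limit and not a number, like compound 2 and compound 3: the limit of > 64 ug/mL in this assay, at which 3 of the 4 values shown sit. Placing 3,5-difluorophenyl where compound 1 has cyclohexyl gives an at least 2.1-fold higher number from compound 1 to compound 4 (0.33 log units; beyond the scatter), so a second fluorinated phenyl group, after the 3-(trifluoromethyl)phenyl of compound 3, also stands clear of compound 1. The steps from compound 2 and from compound 3 to compound 4 cannot be read, since both ends are limits.

Going by these compounds, the order among compound 2, compound 3 and compound 4 stays open. So does whether an unsubstituted benzyl group or a carboxylic acid on that phenyl ring would also reach this limit.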